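A few compounds are considered here, and "the series" means these few. Any claim that something is new, unique, unknown or untested is made for them only; others in the source may bear on it.

Working notes on the series. The three measured compounds share one core and differ in their substituents. Compound 1 `Cc1ccc(-c2ccc3c(c2)C(=O)C(=O)N3)cc1` in a functional assay on HepG2 cells (Homo sapiens) for antiproliferative activity, read by MTT assay, with a stated time of 48 h (on this read-out higher numbers stand for weaker inhibition and lower numbers for stronger inhibition), gives 6000 nM. Compound 2 `COc1ccc(-c2ccc3c(c2)C(=O)C(=O)N3Cc2ccc(F)cc2)cc1` in this assay gives 1120 nM. Compound 3 `COc1ccc(CN2C(=O)C(=O)c3cc(-c4cccc(OC)c4)ccc32)cc1` in this assay gives 1890 nM, the second highest of the three numbers; its gap to compound 2 lies within the usual scatter, while compound 1 stands beyond the scatter at the higher end. Compound 4 `COc1ccc(CN2C(=O)C(=O)c3cc(-c4ccc(C(F)(F)F)cc4)ccc32)cc1` is not yet measured. Its change from compound 3: 4-(trifluoromethyl)phenyl in place of 3-methoxyphenyl on an aromatic carbon. For the measured compounds named here, no measured pair isolates this change, so the expected step is none beyond the scatter, with no clear direction; the expectation is a 1.3-fold lower number from compound 3 to compound 4 (0.10 log units; within the scatter). The estimate for compound 4 in this assay is 1500 nM, with a range from 500 nM to 5000 nM.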

Compound 4, half-maximal inhibitory concentration: 820 nM
For compound 4 the middle estimate is 1.8-fold (0.26 log units) above the measured one; the measured number falls inside the stated range.
By their numbers in this assay, from the lowest: compounds 4, 2 and 3 (each within the scatter of the next, the first and the last beyond it); then compound 1.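

In this assay, for the compounds shown here, the aryl group on this aromatic carbon of the shared core proves not to be silent: 4-(trifluoromethyl)phenyl in place of 3-methoxyphenyl gives a 2.3-fold lower number from compound 3 to compound 4 (0.36 log units; beyond the scatter) and is the first single-place step. The step is modest, and no measured data bear on what lies behind it. The compounds shown leave open whether the step follows the trifluoromethyl group or its position on the phenyl ring. On these data alone, how a phenyl ring carrying an amine or a carboxylic acid would read here also remains open.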